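The source may hold more compounds than are shown below. What is called first, only, known or untested is meant among the compounds shown, and "the series" means these compounds.

Compound 2, `CC(C)S(=O)(=O)c1ccc(S(=O)(=O)N2CCC[C@@H](C(=O)N3CCC(F)(F)CC3)C2)cc1`, is the starting point. In an ADME assay on microsomes from liver (Homo sapiens) for metabolic stability, read by LC-MS, using NADPH, with a stated time of 60 min, tested at 10 uM (on this read-out higher numbers stand for a longer-lived compound and lower numbers for a shorter-lived compound), compound 2 gives > 1 h, which is a limit of the assay rather than a number. Compound 1, `O=C([C@@H]1CCCN(S(=O)(=O)c2ccc(S(=O)(=O)C3CCC3)cc2)C1)N1CCC(F)(F)CC1`, gives > 1 h in this assay, again a limit. Both values sit at the limit of > 1 h in this assay, at which 2 of the 2 values shown sit, so the step from compound 1 to compound 2, a step that the two limits leave unreadable from compound 1 to compound 2, cannot be sized. The new compound 3, `CN(C)S(=O)(=O)c1ccc(S(=O)(=O)N2CCC[C@@H](C(=O)N3CCC(F)(F)CC3)C2)cc1`, carries dimethylamino in place of isopropyl on a sulfonyl sulfur. Going by the values given here, the only measured step bearing on this place is a step that the two limits leave unreadable from compound 1 to compound 2, which is unreadable, so no direction beyond the scatter is expected. Compound 3 is therefore expected to show a step that the limit leaves unreadable from compound 2 to compound 3. The estimate for compound 3 is 1.5 h, between 0.6 h and 4 h.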

Compound 3, half-life: > 1 h
Compound 3 was reported as a limit; the forecaster's own chance of this, stated with the estimate: 70%; the middle value does not contradict the limit.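

In this assay, no new step can be read among compound 1, compound 2 and compound 3, because each value is a limit: the limit of > 1 h in this assay, at which 3 of the 3 values shown sit. The compounds shown leave open whether cyclobutyl, isopropyl and dimethylamino on the sulfonyl sulfur differ at all in half-life.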